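A few compounds are considered here, and "the series" means these few. Any claim that something is new, unique, unknown or untested is made for them only; others in the source may bear on it.

Two compounds of this set share one core and differ only in a single group on an aromatic carbon. In a functional assay on PC-3 cells (Homo sapiens) for inhibition (on this read-out higher numbers stand for weaker inhibition and lower numbers for stronger inhibition), compound 1 `COc1cc2nc(N3CCN(S(=O)(=O)c4ccc(Cl)cc4)CC3)nc(N)c2cc1OC` gives 23000 nM, and compound 2 `COc1cc2nc(N3CCN(S(=O)(=O)c4ccc([N+](=O)[O-])cc4)CC3)nc(N)c2cc1OC` gives 36000 nM. The step of a 1.6-fold higher number from compound 1 to compound 2 (0.19 log units; within the scatter) is the only measured one. Compound 2 stands at the higher of the two numbers, though its gap to compound 1 lies within the scatter, so no order between the two is claimed. Compound 3 `COc1cc2nc(N3CCN(S(=O)(=O)c4ccc(C(F)(F)F)cc4)CC3)nc(N)c2cc1OC` arises from compound 2 by trifluoromethyl in place of nitro on an aromatic carbon. Among the measured compounds shown here, no measured step exchanges a nitro for a trifluoromethyl; the one step at this place, from chloro to nitro, stayed within the scatter, and that is all the data offer as a bearing. Compound 3 is therefore expected to move little in this assay, with a 1.3-fold lower number from compound 2 to compound 3 (0.11 log units; within the scatter) expected to remain within the scatter. The estimate for compound 3 is 28000 nM, within a range from 10000 nM to 70000 nM.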

Compound 3, half-maximal inhibitory concentration: 27000 nM
Compound 3: the middle estimate sits 1.0-fold (0.02 log units) above what was measured, and the stated range covers the measured number.
By their numbers in this assay, from the lowest: compounds 1, 3 and 2 (each within the scatter of the next).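

In this assay, trifluoromethyl in place of nitro gives a 1.3-fold lower number from compound 2 to compound 3 (0.12 log units; within the scatter), and trifluoromethyl in place of chloro gives a 1.2-fold higher number from compound 1 to compound 3 (0.07 log units; within the scatter). Among the compounds shown here, on this aromatic carbon, para to a large group, three different groups now stand within the scatter of one another, with no compound going against that, and the exchange of nitro for trifluoromethyl removes the hydrogen-bond acceptors of the nitro group with no readable shift. Nothing in the data accounts for this flat result.

The compounds shown leave open whether an amine, a carboxylic acid or a longer alkyl chain on this carbon would stay within the same scatter. They also leave open how the number responds to any change outside this one group, since all three compounds share the rest of their structure.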